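Replacing the fluorinated ring of compound 3

The compounds below may be only part of what the source reports. "The series", "measured", "known", "first", "only" and "open" are said of these compounds alone.

Compound 1 `COc1ccc(/C=C/C(=O)C(=Cc2ccc(O)c(F)c2)C(=O)/C=C/c2ccc(OC)cc2OC)c(OC)c1` gives 2830 nM
Compound 2 `COc1cc(OC)c(/C=C/C(=O)C(=Cc2ccc(O)c(OC)c2)C(=O)/C=C/c2c(OC)cc(OC)cc2OC)c(OC)c1` gives 1350 nM
Compound 3 `COc1cc(OC)c(/C=C/C(=O)C(=Cc2ccc(O)c(F)c2)C(=O)/C=C/c2c(OC)cc(OC)cc2OC)c(OC)c1` gives 1580 nM

All three numbers come from a functional assay on CNE-2 cells (Homo sapiens) for antiproliferative activity, read by sulforhodamine B assay, with a stated time of 48 h; a higher number here means a weaker inhibitor, a lower number a stronger inhibitor. Compound 3, at 1580 nM, lies within the scatter of both compound 1 and compound 2, so its place among the three carries little weight.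

The compound still to be measured is compound 4 `COc1cc(OC)c(/C=C/C(=O)C(=Cc2cc(OC)c(O)c(OC)c2)C(=O)/C=C/c2c(OC)cc(OC)cc2OC)c(OC)c1`, and it differs from compound 3 by one change: 4-hydroxy-3,5-dimethoxyphenyl in place of 3-fluoro-4-hydroxyphenyl on a double-bonded chain carbon bound to a double-bonded chain carbon. For the measured compounds named here, one measured step bears on this change. Fluoro in place of methoxy on an aromatic carbon gave a 1.2-fold higher number from compound 2 to compound 3 (0.07 log units; within the scatter), so that exchange alone moved the number by no more than the scatter. Going by the values given here, compound 4 also has methoxy instead of fluoro, as compound 2 does, but no measured step covers the full 4-hydroxy-3,5-dimethoxyphenyl group, and this remains the open part of the comparison.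

The expectation is therefore a small step at most, with compound 4 landing near compound 2 at 1350 nM. The estimated step is a 1.2-fold lower number from compound 3 to compound 4 (0.08 log units; within the scatter), which means no expected change beyond the scatter. For compound 4 the estimated value is 1300 nM, with an expected range from 600 nM to 2800 nM in this assay.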

Compound 4, half-maximal inhibitory concentration: 680 nM
Compound 4: middle estimate off by 1.9-fold (0.28 log units), on the high side, within the range that was stated.
By their numbers in this assay, from the lowest: compounds 4, 2, 3 and 1 (each within the scatter of the next, the first and the last beyond it).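

In this assay, 4-hydroxy-3,5-dimethoxyphenyl in place of 3-fluoro-4-hydroxyphenyl on a double-bonded chain carbon bound to a double-bonded chain carbon gave a 2.3-fold lower number from compound 3 to compound 4 (0.37 log units; beyond the scatter) and so moved the number beyond the scatter, which the earlier exchange at this position did not do, with fluoro in place of methoxy giving a 1.2-fold higher number from compound 2 to compound 3 (0.07 log units; within the scatter) only. Methoxy in place of hydrogen on an aromatic carbon gave a 2.0-fold lower number from compound 2 to compound 4 (0.30 log units; within the scatter) and on its own cannot be told from the scatter, so the clear difference appears only across the full exchange, in which fluoro gives way to methoxy and a further methoxy enters on the same ring. Nothing available here accounts for this step at the position.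

The compounds shown leave open whether both methoxy groups are needed for this step and whether the same exchange would give a similar step on the core of compound 1. Every group shown at this position also keeps its hydroxy, and how an amine or a carboxylic acid in its place would read in this assay remains unknown.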